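A few compounds are considered here, and "the series" means these few. Any claim that something is new, unique, unknown or untested is made for them only; others in the source may bear on it.

Measured so far:
compound 1 `CC(C)COc1nc(C(C)(C)C)ccc1CNC(=O)C(C)c1ccc(NS(C)(=O)=O)c(F)c1`: 0.6 nM
compound 2 `CC(C(=O)NCc1ccc(C(C)(C)C)nc1OCc1ccccc1)c1ccc(NS(C)(=O)=O)c(F)c1`: 4.4 nM

Going by the values given here, in an assay on cells for antagonist activity at transient receptor potential cation channel subfamily V member 1 (Homo sapiens), read by FLIPR and calcium flux, with a stated time of 6 min (a lower number here means a stronger inhibitor, a higher number a weaker inhibitor), compound 2 gives the higher of these two numbers; the only measured step, a 7.3-fold higher number from compound 1 to compound 2 (0.87 log units; beyond the scatter), separates it from compound 1. Compound 3 `CCCCCCSc1nc(C(C)(C)C)ccc1CNC(=O)C(C)c1ccc(NS(C)(=O)=O)c(F)c1` differs from compound 2 in one place: hexylsulfanyl in place of benzyloxy on an aromatic carbon. Among the compounds with values here, no measured step covers this exchange; the step from compound 1 to compound 2 changes the same position but with a different group, so it serves only as a rough scale. A modest step in either direction is therefore expected, not a large one. Compound 3 is estimated to give 2.5 nM in this assay, with a range of 0.5 nM to 12 nM, meaning a 1.8-fold lower number from compound 2 to compound 3 (0.25 log units; within the scatter).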

Compound 3, inhibition constant: 1.5 nM
Estimate against measurement, compound 3: 1.7-fold (0.22 log units) above, and the stated range covers the measured number.
By their numbers in this assay, from the lowest: compound 1; then compound 3; then compound 2.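

In this assay, this position tolerates a hexylsulfanyl chain, which has no ring and links through sulfur rather than oxygen: replacing benzyloxy gives a 2.9-fold lower number from compound 2 to compound 3 (0.47 log units; beyond the scatter), while replacing isobutoxy gives a 2.5-fold higher number from compound 1 to compound 3 (0.40 log units; beyond the scatter). Compound 3 therefore sits between the two oxygen-linked compounds, with both steps beyond the scatter. No supporting evidence accounts for these shifts. The compounds shown do not separate the effect of sulfur from that of chain shape, which hexyloxy or isobutylsulfanyl could address. On these data alone, how an amine would behave at this position also remains open.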